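From compound 3 to compound 4: a larger aromatic group

The source may hold more compounds than are shown below. What is called first, only, known or untested is meant among the compounds shown, and "the series" means these compounds.

In a toxicity assay on NIH3T3 cells (Mus musculus) for cytotoxicity, read by resazurin assay (a lower number here means that less compound is needed, a higher number that more compound is needed for the effect), compound 1 `c1ccc(-c2ccc(Cn3cncc3CNc3ccc(-c4ccccc4)c(-c4ccccc4)c3)cc2)cc1` gives > 10000 nM, which is a limit. Compound 2 `c1ccc(-c2ccc(Cn3cncc3CNc3ccc(-c4cncs4)c(-c4ccccc4)c3)cc2)cc1` gives > 1000 nM, also a limit. Compound 3 `c1ccc(-c2ccc(Cn3cncc3CNc3ccc(-c4ccc[nH]4)c(-c4ccccc4)c3)cc2)cc1` gives > 10000 nM, again a limit and not a number. Compound 3 therefore has no exact place in the series, and its group is the limit of > 10000 nM in this assay, at which 2 of the 3 values shown sit.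

Compound 4 `c1ccc(-c2ccc(Cn3cncc3CNc3ccc(-c4onc5ccccc45)c(-c4ccccc4)c3)cc2)cc1` differs from compound 3 by a group of 9 heavy atoms (7 carbon, 1 nitrogen, 1 oxygen; one five-membered aromatic ring with 2 hetero atoms, one six-membered aromatic ring of carbon only) in place of a group of 5 heavy atoms (4 carbon, 1 nitrogen; one five-membered aromatic ring with 1 hetero atom), on an aromatic carbon. The site is para to a large group and ortho to a phenyl group.

For the measured compounds named here, three measured steps concern this same site: a step that the two limits leave unreadable from compound 1 to compound 2, a step that the two limits leave unreadable from compound 1 to compound 3 and a step that the two limits leave unreadable from compound 2 to compound 3. Going by the values given here, none of them gives a size, so the series offers no measured step to carry over to the new group. Among the compounds with values here, all three groups tested at this site ended in a limit, and that is the only guide available. No step beyond the scatter is therefore expected in this assay, and compound 4 is more likely than not to end in a limit as well. The expected change is a number no higher from compound 3 to compound 4 (the limit leaves the size open), an estimate that carries no firm direction. The estimate for compound 4 is 10000 nM, with an expected range from 2000 nM to 30000 nM.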

Compound 4, half-maximal effective concentration: > 10000 nM
Compound 4: only a limit was reported; the forecaster's own chance of this, stated with the estimate: 75%; the middle value lies on the limit itself.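

In this assay compound 4 gives > 10000 nM, which is a limit and not a number. For the compounds shown here, compounds 1, 2, 3 and 4 all end in limits, so no step among them can be read. The compounds shown leave open the concentration at which any of them reaches the half-maximal effect in this assay, and whether the groups at this site differ at all.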